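The source may hold more compounds than are shown below. What is called first, only, known or untested is meant among the compounds shown, and "the series" means these compounds.

Measured so far in a physicochemical assay for lipophilicity, at pH 7.4; a higher number here means a more lipophilic compound, a lower number a more polar compound: compound 1 `CNC(=O)c1sc(N2CC3CC2(CNC(=O)c2c[nH]c4ncc(C(F)(F)F)cc24)C3)nc1C(F)(F)F` gives 4.2; compound 2 `COc1cc2c(Nc3cnc(OCCCC4CCCC4)nc3)ncnc2cc1OCCCN1CCCCC1` gives 4.5; compound 3 `CS(=O)(=O)c1cnc(Nc2ccc(O)cc2)nc1NCc1ccccc1` gives 2.8.

Compound 1 stands second highest of the three numbers. Its nearest neighbour is compound 2, whose value lies higher by an amount within the scatter, so the two cannot be ordered. Compound 3 lies furthest off, well beyond the scatter and lower than compound 1. No pair of these compounds differs in only one place, so no single step between measured compounds is known.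

Compound 4 `CNC(=O)c1sc(N2CC3CC2(CNC(=O)c2c[nH]c4ncc(Cl)cc24)C3)nc1C(F)(F)F` is the next compound. It differs from compound 1 in one place: chloro in place of trifluoromethyl on an aromatic carbon. Within the data shown here, with no measured step of this kind to lean on, compound 4 is expected to show a small decrease, around the edge of the scatter, with a step of a number 0.30 log units lower from compound 1 to compound 4 (within the scatter). Compound 4 is therefore estimated at 3.9, within a range from 3.5 to 4.3.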

Compound 4, distribution coefficient: 4
For compound 4 the middle estimate is 0.10 log units below the measured one, and the stated range covers the measured number.
By their numbers in this assay, from the lowest: compound 3; then compounds 4, 1 and 2 (each within the scatter of the next, the first and the last beyond it).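

In this assay, chloro in place of trifluoromethyl on this aromatic carbon gives the first step in one place among these compounds, a number 0.20 log units lower from compound 1 to compound 4 (within the scatter), so the two groups cannot be told apart at this position on the shared core. Nothing available bears on the reason for this result. Going by these compounds, whether an amine, a carboxylic acid or a nitrile at this position would also stay within the scatter remains open. So does whether the same change on another aromatic carbon would give a similar step.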